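Ring closure on the alkoxy chain of compound 3

The compounds below may be only part of what the source reports. "The series", "measured", "known", "first", "only" and "open" are said of these compounds alone.

Of the compounds shown here, three sharing one core have been measured in a functional assay for inhibition of transient receptor potential cation channel subfamily V member 1 (Homo sapiens), read by fluorescence and calcium flux; a lower number here means a stronger inhibitor, a higher number a weaker inhibitor. Compound 1 `CC(C)c1cc2nc(N)nc(O)c2cc1-c1ccc(Cl)cc1` gives 133 nM. Compound 2 `CCOc1cc(-c2cc3c(O)nc(C)nc3cc2C(C)C)ccc1Cl` gives 12 nM, and compound 3 `CCCCOc1cc(-c2cc3c(O)nc(C)nc3cc2C(C)C)ccc1Cl` gives 82 nM. Among these three numbers compound 3 stands second highest: its nearest neighbour is compound 1, whose number is lower by an amount within the scatter, while compound 2 lies well apart, with a number beyond the scatter below it.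

Compound 4 `Cc1nc(O)c2cc(-c3ccc(Cl)c(OCC4CCC4)c3)c(C(C)C)cc2n1` differs from compound 3 by cyclobutyl in place of propyl on a saturated chain carbon bound to an oxygen on an aromatic ring. Within the data shown here, only one measured step touches this region: the step of a 6.8-fold higher number from compound 2 to compound 3 (0.83 log units; beyond the scatter), where the chain grew by an ethyl group. Among the measured compounds shown here, the change to compound 4 adds a single carbon but also closes a ring, and no measured pair shows what ring closure does here. The step from compound 3 to compound 4 is therefore expected to be small, a 1.1-fold higher number from compound 3 to compound 4 (0.04 log units; within the scatter), with no clear direction beyond the scatter. Compound 4 is expected to give about 90 nM in this assay, within a range from 30 nM to 270 nM.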

Compound 4, half-maximal inhibitory concentration: 144 nM
For compound 4 the middle estimate is 1.6-fold (0.20 log units) below the measured one; measured number inside the range.
By their numbers in this assay, from the lowest: compound 2; then compounds 3, 1 and 4 (each within the scatter of the next).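

In this assay the step from the butoxy chain to cyclobutylmethoxy is a 1.8-fold higher number from compound 3 to compound 4 (0.24 log units; within the scatter) and so does not separate the ring from the open chain at this place. Compound 2, with its ethoxy group, stands well apart from both, with a 6.8-fold higher number from compound 2 to compound 3 (0.83 log units; beyond the scatter) and a 12-fold higher number from compound 2 to compound 4 (1.08 log units; beyond the scatter) as the two steps, so the ring does not bring back the low number of compound 2 any more than the butyl chain does. Nothing available offers a reason for these numbers.

The compounds shown leave open whether a propoxy chain already gives a number like that of compound 3 or one like that of compound 2. They also leave open whether a smaller ring, as in cyclopropylmethoxy, would behave like the cyclobutyl group of compound 4.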